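The source may report more compounds than this note shows. Statements on the series, on what has been measured and on what is new or still open speak of the compounds shown alone.

Compounds measured so far in a functional assay on MCF7 cells (Homo sapiens) for inhibition, read by sulforhodamine B assay, with a stated time of 48 h; a higher number here means a weaker inhibitor of growth, a lower number a stronger inhibitor of growth:
- Compound 1 `O=C(CCl)NC(=O)Nc1ccc(C2CCCCC2)cc1` gives 1500 nM
- Compound 2 `O=C(CCl)NC(=O)Nc1ccc(-c2ccccc2)cc1` gives 3900 nM
- Compound 3 `CC(C)(C)c1ccc(NC(=O)NC(=O)CCl)cc1` gives 4800 nM

Compound 3 lies close to one neighbour (a 1.2-fold higher number from compound 2 to compound 3 (0.09 log units; within the scatter)) and apart from the other (a 3.2-fold higher number from compound 1 to compound 3 (0.51 log units; beyond the scatter)). Compound 4 `O=C(CCl)NC(=O)Nc1ccc(I)cc1` has not yet been measured. It carries iodo in place of tert-butyl on an aromatic carbon. All three measured steps exchange the group at this same place, so all bear on the change. For the measured compounds named here, only the steps away from cyclohexyl exceed the scatter, as in the case of a 2.6-fold higher number from compound 1 to compound 2 (0.41 log units; beyond the scatter) and the step to compound 3 above, and even those are modest. Going by the values given here, no measured step brings in iodo, so the data show no direction for this change. In this assay a step within the scatter is therefore expected, or a modest one at most, either way. The estimated step is a 1.0-fold higher number from compound 3 to compound 4 (0.02 log units; within the scatter) and no more than that. The expected value for compound 4 is 5000 nM, with an estimated range from 2000 nM to 12000 nM.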

Compound 4, concentration for 50% growth inhibition: 6800 nM
Compound 4: the middle estimate sits 1.4-fold (0.13 log units) below what was measured, within the range that was stated.
By their numbers in this assay, from the lowest: compound 1; then compounds 2, 3 and 4 (each within the scatter of the next).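

In this assay, iodo, which has fewer heavy atoms than tert-butyl and no carbon, gives a 1.4-fold higher number from compound 3 to compound 4 (0.15 log units; within the scatter) and, in place of phenyl, a 1.7-fold higher number from compound 2 to compound 4 (0.24 log units; within the scatter) at this position, so these exchanges among compound 2, compound 3 and compound 4 leave growth inhibition within the scatter. Cyclohexyl alone stands apart, with a 4.5-fold higher number from compound 1 to compound 4 (0.66 log units; beyond the scatter) as the largest step yet seen here, and compound 1 remains the strongest inhibitor of the four, its steps to all the others lying beyond the scatter. No measurement is available that would explain these differences.

Going by these compounds, whether a smaller halogen such as fluoro or chloro, an amine or a carboxylic acid at this place would fit the same narrow spread remains open. Also open, on these data alone, is whether a longer alkyl chain or a larger saturated ring would extend the advantage seen with cyclohexyl.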